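Two limits and one open step in cytotoxicity

The source may report more compounds than this note shows. Statements on the series, on what has been measured and on what is new or still open speak of the compounds shown alone.

Compound 1 `COC(=O)c1cc(C2=C(c3cc(OC)c(OC)c(OC)c3)C(=O)CC2O[SiH2]C(C)(C)C)ccc1OC`: > 100 ug/mL
Compound 2 `COc1cc(C2=C(c3ccccc3)C(O[SiH2]C(C)(C)C)CC2=O)cc(OC)c1OC`: > 100 ug/mL

The two compounds were tested in an ADME assay on HEK293 cells (Homo sapiens) for cytotoxicity, read by MTT assay, with a stated time of 72 h; on this read-out lower numbers stand for stronger inhibition and higher numbers for weaker inhibition. Compound 1 gives > 100 ug/mL, which is a limit and not a number. Compound 2 gives > 100 ug/mL, which is likewise a limit, so its position is known only as a limit and not as a number.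

The next compound, compound 3 `COCOc1cc(C2=C(c3cc(OC)c(OC)c(OC)c3)C(=O)CC2O[SiH2]C(C)(C)C)ccc1OC`, differs from compound 2 by 4-methoxy-3-(methoxymethoxy)phenyl in place of phenyl on a double-bonded ring carbon. In words, 4-methoxy-3-(methoxymethoxy)phenyl stands in place of phenyl on a double-bonded ring carbon.

Going by the values given here, one measured step bears on this change: a step that the two limits leave unreadable from compound 1 to compound 2. That step also exchanges a substituted phenyl and phenyl on a double-bonded ring carbon, but it has no readable size. All the data show is the limit of > 100 ug/mL in this assay, at which 2 of the 2 values shown sit. It therefore offers no size and no direction for the new change, and a step beyond the scatter in this assay is not expected from it.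

The expected outcome is a step that the limit leaves unreadable from compound 2 to compound 3. Compound 3 is estimated at 120 ug/mL, with an expected range from 50 ug/mL to 300 ug/mL.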

Compound 3, half-maximal inhibitory concentration: > 100 ug/mL
Compound 3: no number, only a limit (the forecaster's own chance of this, stated with the estimate: 75%); the middle value is on the limit's open side.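

In this assay compound 3 gives > 100 ug/mL, which is a limit and not a number. No step among compound 1, compound 2 and compound 3 can be read, and the data show only this: the limit of > 100 ug/mL in this assay, at which 3 of the 3 values shown sit.

The compounds shown leave open how these three compare in this assay, since none of them has a numerical value there.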